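From tert-Butyl to Fluoro in a Growth Assay

The source may report more compounds than this note shows. Statements on the series, on what has been measured and on what is new or still open speak of the compounds shown alone.

In a functional assay on A-375 cells (Homo sapiens) for inhibition, read by CCK-8 assay, with a stated time of 72 h, tested at 8 uM (a lower number here means less inhibition of growth, a higher number more inhibition of growth at the concentration tested), compound 3 (`CC(C)(C)c1ccc(SCc2ccc(C(=O)Nc3ccccc3N)cc2)cc1`) gives 33.1%, the middle of the three numbers. Compound 1 (`Nc1ccccc1NC(=O)c1ccc(CSc2cccc(F)c2)cc1`) reaches 76.3%, while compound 2 (`Nc1ccccc1NC(=O)c1ccc(CSc2ccc(Br)cc2)cc1`) gives 6.17%. Compound 4 (`Nc1ccccc1NC(=O)c1ccc(CSc2ccc(F)cc2)cc1`) has fluoro in place of tert-butyl on an aromatic carbon, para to a large group (fluoro in place of tert-butyl on an aromatic carbon). Among the measured compounds shown here, two measured steps bear on this change: a number 70.1 percentage points lower from compound 1 to compound 2 (beyond the scatter) and a number 26.9 percentage points higher from compound 2 to compound 3 (beyond the scatter). Both show that changing this aromatic substituent can move the number well beyond the scatter. For the measured compounds named here, compound 1, the only measured compound with a fluoro group, stands highest at 76.3%, although its fluoro sits elsewhere on the ring. A modest rise is therefore expected, a number 11.9 percentage points higher from compound 3 to compound 4 (beyond the scatter). Compound 4 is estimated at 45%, with an expected range of 15% to 75%.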

Compound 4, percent growth inhibition at one concentration: 54.3%
The estimate for compound 4 lay 9.3 percentage points below the measured number; the range from low to high includes it.
By their numbers in this assay, from the lowest: compound 2; then compound 3; then compound 4; then compound 1.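

Fluoro in place of tert-butyl gives a number 21.2 percentage points higher from compound 3 to compound 4 (beyond the scatter) and fluoro in place of bromo gives a number 48.1 percentage points higher from compound 2 to compound 4 (beyond the scatter) so at this carbon, para to a large group, fluoro and bromo fall on either side of tert-butyl. The place of the fluoro also counts, since 4-fluorophenyl in place of 3-fluorophenyl gives a number 22 percentage points lower from compound 1 to compound 4 (beyond the scatter) and the two fluoro compounds therefore do not match. The information at hand gives no reason for these shifts. From the compounds shown here alone, whether chloro, an amine or a nitrile on this carbon would stand nearer fluoro or bromo remains open.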